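This account rests on a few compounds, and the source may have more. Where it says the series, first, only, none or still open, it means among the compounds named here.

Measured so far:
compound 1, `C=C(C)[C@@H]1CC=C(Cn2cc(COc3ccc(C4NC(=O)NC(C)=C4C(C)=O)cc3)nn2)CC1`, 49300 nM
compound 2, `C=C(C)[C@@H]1CC=C(Cn2cc(COc3cccc(C4NC(=O)NC(C)=C4C(C)=O)c3)nn2)CC1`, 49800 nM
compound 3, `C=C(C)[C@@H]1CC=C(Cn2cc(COc3cc(C4NC(=O)NC(C)=C4C(C)=O)ccc3OC)nn2)CC1`, a limit of > 100000 nM

In a functional assay on PC-3 cells (Homo sapiens) for inhibition, read by sulforhodamine B assay, with a stated time of 48 h (on this read-out higher numbers stand for weaker inhibition of growth and lower numbers for stronger inhibition of growth), compound 1 gives 49300 nM and compound 2 gives 49800 nM; the two values lie within the scatter of each other. The difference between the cores of compound 1 and compound 2 is not broken down here. Compound 3 gives only a limit in this assay, > 100000 nM. From compound 2 to compound 3 the change is methoxy in place of hydrogen on an aromatic carbon, and the step is an at least 2.0-fold higher number from compound 2 to compound 3 (0.30 log units; that floor lies within the scatter), bounded by the limit of > 100000 nM in this assay, at which 1 of the 3 values shown sits. Compound 4, `C=C(C)[C@@H]1CC=C(Cn2cc(COc3ccc(C4NC(=O)NC(C)=C4C(C)=O)cc3OC)nn2)CC1`, is not yet measured in this assay. It differs from compound 1 by methoxy in place of hydrogen on an aromatic carbon, the same kind of change, though here the methoxy sits meta to a large group rather than para to a large group. Compound 4 is expected to move by a 2.0-fold higher number from compound 1 to compound 4 (0.31 log units; beyond the scatter). That expectation rests on an at least 2.0-fold higher number from compound 2 to compound 3 (0.30 log units; that floor lies within the scatter) and on the value of compound 1, 49300 nM. Compound 4 is estimated at 100000 nM in this assay.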

Compound 4, concentration for total growth inhibition: 85700 nM
Compound 4: middle estimate off by 1.2-fold (0.07 log units), on the high side, within the range that was stated.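

In this assay, methoxy in place of hydrogen on an aromatic carbon gives a 1.7-fold higher number from compound 1 to compound 4 (0.24 log units; within the scatter), so on this core the change yields a step that cannot be told from repeat measurement. Both steps run in the same direction, but that is all the comparison supports: the same change on two cores in this assay, an at least 2.0-fold higher number (0.30 log units; that floor lies within the scatter) from compound 2 to compound 3 and a 1.7-fold higher number (0.24 log units; within the scatter) from compound 1 to compound 4; the limit leaves it open whether they differ. The series therefore does not show how closely the size of the step carries from one core to the other, and the step to compound 3 remains only a floor: the limit of > 100000 nM in this assay, at which 1 of the 4 values shown sits.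

The compounds shown leave open how a hydroxyl, an ethoxy or a fluorine on the same aromatic carbon would read in this assay. They also leave open whether an amine there would behave differently.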